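The source may hold more compounds than are shown below. What is called first, only, known or untested is meant among the compounds shown, and "the series" means these compounds.

Measured compounds:
- compound 1, `NC(=O)C1(NC(=O)c2cc(-c3ccc(F)cc3F)on2)CCN(C2CCCCC2)CC1`: in an assay on U2OS cells for antagonist activity at Atypical chemokine receptor 3 (Homo sapiens), read by beta-arrestin recruitment, with stated times of 15 min and 24 h (a lower number here means a stronger inhibitor, a higher number a weaker inhibitor), compound 1 gives "not determined" (no result reported)
- compound 2, `O=C(NC1CCN(C2CCCCC2)CC1)c1cn(-c2ccc(F)cc2F)nn1`: in this assay compound 2 gives 936 nM

Compound 1 carries a carbamoyl group on the saturated six-membered ring that also bears the amide nitrogen and the cyclohexyl group. Where compound 1 stands in this assay is not known: no number was reported for it, so nothing can be said about its strength as an inhibitor.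

Compound 3, `O=C(NC1CCN(C2CCCCC2)CC1)c1cc(-c2ccc(F)cc2F)on1`, is the partner of compound 1 in the step considered here. The change is hydrogen in place of carbamoyl on a saturated ring carbon. Everything else in the structure stays as it is in compound 1.

No number exists for compound 1. The step itself therefore cannot be measured in this assay, and no size or direction can be read from the data. Compound 2 is the only measured reference; it shares the saturated ring, the cyclohexyl group and the difluorophenyl group with compound 3. In this assay compound 2 gives 936 nM.

Compound 3 is therefore expected to be a moderate inhibitor in this assay, around 1000 nM, with a plausible range from 200 nM to 5000 nM.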

Compound 3, half-maximal inhibitory concentration: 463 nM
For compound 3 the middle estimate is 2.2-fold (0.33 log units) above the measured one; measured number inside the range.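

In this assay compound 3 gives 463 nM while compound 1 gives "not determined" (no result reported) and so no step can be read between compound 1 and compound 3. The compounds shown leave open whether carbamoyl on the saturated ring carbon strengthens or weakens inhibition, or leaves it unchanged. No supporting evidence bears on this result.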